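Notes on the step from compound 1 to compound 4

This account rests on a few compounds, and the source may have more. Where it says the series, first, only, none or still open, it means among the compounds named here.

Measured in a functional assay on HUVEC cells (Homo sapiens) for antiproliferative activity, read by MTT assay, with a stated time of 48 h; a lower number here means a stronger inhibitor, a higher number a weaker inhibitor:
compound 1 `Brc1cccc(/C=C/c2nnc(-c3ccc4c(c3)OCCO4)o2)c1`: 13500 nM
compound 2 `O=[N+]([O-])c1ccc(/C=C/c2nnc(-c3ccc4c(c3)OCCO4)o2)cc1`: 32100 nM
compound 3 `Clc1ccccc1/C=C/c1nnc(-c2ccc3c(c2)OCCO3)o1`: 7710 nM

Compound 1 lies within the scatter of compound 3 in this assay, while compound 2 gives a higher number than either, and its gap to compound 1 lies beyond the scatter. Compound 4 `COc1ccc(/C=C/c2nnc(-c3ccc4c(c3)OCCO4)o2)cc1` has not yet been measured. It keeps the core of compound 1 and carries 4-methoxyphenyl in place of 3-bromophenyl on a double-bonded chain carbon bound to a double-bonded chain carbon.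

Going by the values given here, one measured step bears directly on this exchange, since it also replaces the group at that place: a 1.8-fold lower number from compound 1 to compound 3 (0.24 log units; within the scatter). That step stays within the scatter. The higher number of compound 2, at 32100 nM, shows that a larger gap cannot be ruled out for a group exchanged at this place. Among the compounds with values here, no measured compound carries 4-methoxyphenyl, so the data give no direction. No shift beyond the scatter is expected, and the estimated step is a 1.0-fold higher number from compound 1 to compound 4 (0.02 log units; within the scatter). The expected value for compound 4 is 14000 nM, with an estimated range of 5500 nM to 32000 nM.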

Compound 4, half-maximal inhibitory concentration: > 50000 nM
Compound 4: no number, only a limit; the forecaster's own chance of this, stated with the estimate: 3%; middle value at least 3.5-fold (0.55 log units) from the limit.
By their numbers in this assay, from the lowest: compounds 3 and 1 (each within the scatter of the next); then compound 2. At a limit, above all of these: compound 4.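

In this assay, compound 4 gives no number, only a limit: the limit of > 50000 nM in this assay, at which 1 of the 4 values shown sits.

Going by these compounds alone, at the double-bonded chain carbon bound to a double-bonded chain carbon, the choice of aryl group can therefore matter beyond the scatter: an at least 3.7-fold higher number from compound 1 to compound 4 (0.56 log units; beyond the scatter) and an at least 6.4-fold higher number from compound 3 to compound 4 (0.81 log units; beyond the scatter), whereas the one earlier step at this place, a 1.8-fold lower number from compound 1 to compound 3 (0.24 log units; within the scatter), stayed within it. The comparison with the nitro compound is less decisive, with an at least 1.5-fold higher number from compound 2 to compound 4 (0.19 log units; that floor lies within the scatter), so methoxy in place of nitro on an aromatic carbon cannot yet be placed in order, and compound 4 may lie close to compound 2 or far from it.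

The size of the loss with 4-methoxyphenyl stays open, as only its floor is known, and the compounds shown cannot separate the contribution of the methoxy group from that of where it stands on the ring. Also open, going by these compounds, is how this place would respond to an amine, a carboxylic acid or a longer alkoxy chain on the aromatic ring, and whether any such group would return the value to the range of compound 1 and compound 3.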